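The compounds below may be only part of what the source reports. "The series", "measured", "known", "first", "only" and "open" are said of these compounds alone.

Of the compounds shown here, three sharing one core have been measured in a functional assay (aorta) with Rattus norvegicus as the target; on this read-out higher numbers stand for an effect only at larger amounts of compound and lower numbers for an effect already at smaller amounts. Compound 1 `COc1ccc(-c2nc(/N=C(\N)N(C)C)sc2-c2ccc(OC)cc2)cc1` gives 4.8 uM, compound 2 `COc1ccc(-c2nc(/N=C(\N)[N+]3(C)CCCCC3)sc2-c2ccc(OC)cc2)cc1` gives 21 uM, and compound 3 `COc1ccc(-c2nc(CNC(=O)c3cccnc3)sc2-c2ccc(OC)cc2)cc1` gives 8.2 uM. Compound 3 therefore stands level with compound 1 and apart from compound 2: a 1.7-fold higher number from compound 1 to compound 3 (0.23 log units; within the scatter) stays within the scatter, while a 2.6-fold lower number from compound 2 to compound 3 (0.41 log units; beyond the scatter) goes beyond it.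

The next compound, compound 4 `CCN(CC)C(=O)c1nc(-c2ccc(OC)cc2)c(-c2ccc(OC)cc2)s1`, keeps both 4-methoxyphenyl groups and has diethylcarbamoyl in place of (((pyridin-3-yl)carbonyl)amino)methyl on an aromatic carbon. That carbon lies next to the ring nitrogen and next to the ring sulfur.

The measured steps all alter the group at this carbon, or a part of that group, so they are the best guide available. Even the largest of them, a 4.4-fold higher number from compound 1 to compound 2 (0.64 log units; beyond the scatter), is only modest, and these very different groups all remain close together in this assay. Among the measured compounds shown here, no measured compound carries diethylcarbamoyl, so this particular group remains untested. A shift beyond the scatter is not expected in either direction, although a modest one cannot be excluded. The expected step is a 1.0-fold lower number from compound 3 to compound 4 (0.01 log units; within the scatter). The estimate for compound 4 is 8 uM, with an expected range from 3 uM to 22 uM.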

Compound 4, concentration for half-maximal effect: 14 uM
Estimate against measurement, compound 4: 1.8-fold (0.24 log units) below; the measured number falls inside the stated range.
By their numbers in this assay, from the lowest: compounds 1, 3, 4 and 2 (each within the scatter of the next, the first and the last beyond it).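

In this assay, the swap to diethylcarbamoyl gives a 1.7-fold higher number from compound 3 to compound 4 (0.23 log units; within the scatter), so at this carbon a group with no ring and no hydrogen-bond donor can stand in for (((pyridin-3-yl)carbonyl)amino)methyl without a shift that can be told from the scatter. The comparison with the other two compounds gives a 1.5-fold lower number from compound 2 to compound 4 (0.18 log units; within the scatter) and a 2.9-fold higher number from compound 1 to compound 4 (0.46 log units; beyond the scatter), which places compound 4 level with compound 2 and compound 3 but apart from compound 1, by a modest step. A carbonyl attached directly to this ring carbon thus stays in the same narrow band as the earlier groups, and no measured evidence is available here to explain the small differences among them.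

Going by these compounds, it remains open whether a much smaller group on this carbon, such as a primary amine or a carboxylic acid, or a longer chain on the amide nitrogen, would stay in this band. All four compounds also keep both 4-methoxyphenyl groups, so the effect of a hydroxyl or a fluorine in place of methoxy cannot be judged from them.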